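Swapping the Aryl Group on the Aniline Nitrogen

The compounds below may be only part of what the source reports. "The series", "measured", "known", "first", "only" and "open" are said of these compounds alone.

The three measured compounds share one core and differ only in the group carried on the aniline nitrogen. Compound 1 `O=C1CCC(N2C(=O)c3ccc(Nc4ccccc4)cc3C2=O)C(=O)N1` gives 6% in an assay on FRT-Jurkat cells for inhibition of nuclear factor NF-kappa-B complex (Homo sapiens), read by flow cytometry, with a stated time of 24 h, tested at 10 uM; a lower number here means less inhibition, a higher number more inhibition at the concentration tested (going by the name of the read-out). Compound 2 `COc1ccc(Nc2ccc3c(c2)C(=O)N(C2CCC(=O)NC2=O)C3=O)cc1` gives 29%, and compound 3 `CCc1ccc(Nc2ccc3c(c2)C(=O)N(C2CCC(=O)NC2=O)C3=O)cc1` gives 5%. Compound 3 thus sits at the bottom of the three numbers, although its gap to compound 1 lies within the scatter; only compound 2 stands clearly apart from it.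

Compound 4 `Cc1ccccc1Nc1ccc2c(c1)C(=O)N(C1CCC(=O)NC1=O)C2=O` has not yet been measured. It differs from compound 3 by 2-methylphenyl in place of 4-ethylphenyl on a nitrogen on an aromatic ring. Among the compounds with values here, two measured steps touch this change. Within the data shown here, the step of a number 1 percentage points lower from compound 1 to compound 3 (within the scatter) shows that adding an ethyl to the phenyl changed nothing beyond the scatter, while the step of a number 24 percentage points lower from compound 2 to compound 3 (beyond the scatter) shows that a methoxy, not an alkyl, gave the only larger number. A methyl in place of an ethyl stays within the alkyl series, so compound 4 is expected to stay near compound 3 with a step of a number 3 percentage points higher from compound 3 to compound 4 (within the scatter). Compound 4 is therefore estimated at 8%, within 0% to 20%.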

Compound 4, a percentage reported as inhibition, at one concentration (the size of the read-out at that concentration, not a potency): 2%
Estimate against measurement, compound 4: 6 percentage points above, and the stated range covers the measured number.
By their numbers in this assay, from the lowest: compounds 4, 3 and 1 (each within the scatter of the next); then compound 2.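

The change to 2-methylphenyl brings a number 3 percentage points lower from compound 3 to compound 4 (within the scatter), and adding the methyl to the plain phenyl brings a number 4 percentage points lower from compound 1 to compound 4 (within the scatter), so in this assay a second alkyl-bearing ring joins compound 3 in staying within the scatter of the unsubstituted phenyl. Compound 2 stays clearly apart, with a number 27 percentage points lower from compound 2 to compound 4 (beyond the scatter), which leaves the 4-methoxyphenyl group as the only one on this nitrogen that stands clear of the other three. No measurement shown here explains why these numbers fall as they do.

As far as these compounds go, it remains open whether an ethoxy group, a hydroxy group or an amine on this phenyl would follow the methoxy of compound 2 or the alkyl groups of compounds 3 and 4. From the compounds shown here alone, a carboxylic acid at that place is equally open.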